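The compounds below may be only part of what the source reports. "The series", "measured", "known", "first", "only" and "open" are said of these compounds alone.

Working notes on the series, read in cytotoxicity terms through one measurement only. In an ADME assay on MRC5 cells (Homo sapiens) for cytotoxicity, read by fluorescence, with a stated time of 72 h (a higher number here means a weaker inhibitor, a lower number a stronger inhibitor), compound 1 `O=[N+]([O-])c1cn2c(n1)O[C@@H](COc1ccc(-c3ccc(F)cc3)nc1)C2` reads > 64000 nM, which is a limit and not a number. Compound 2 `CC1(COc2ccc(-c3ccc(F)nc3)cn2)Cn2cc([N+](=O)[O-])nc2O1` reads > 64000 nM, which is again a limit. Going by the values given here, compound 3 `CC1(COc2ccc(OC(F)(F)F)cc2)Cn2cc(Br)nc2O1` gives 34000 nM, the only true number so far. The readings of compound 1 and compound 2 are limits, so compound 3 cannot be placed by a measured step against either of them.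

The next compound is compound 4 `CSc1cn2c(n1)OC(C)(COc1ccc(OC(F)(F)F)cc1)C2`, still unmeasured in this assay. It differs from compound 3 by a single change: methylsulfanyl in place of bromo on an aromatic carbon. In words, methylsulfanyl stands in place of bromo on an aromatic carbon.

Among the compounds with values here, no measured pair in the set differs in one place, so the size of this change has no direct precedent here. Within the data shown here, the only anchor is compound 3 at 34000 nM, and no shift beyond the usual scatter is expected in either direction. The estimated change is a 1.0-fold lower number from compound 3 to compound 4 (0.01 log units; within the scatter). A report of a limit alone remains possible for the new compound. For compound 4 the expected value is 33000 nM, with an estimated range from 14000 nM to 64000 nM.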

Compound 4, half-maximal inhibitory concentration: 38000 nM
Estimate against measurement, compound 4: 1.2-fold (0.06 log units) below; low and high end bracket the measured number.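

In this assay, going by these compounds alone, the first step that can be read, a 1.1-fold higher number from compound 3 to compound 4 (0.05 log units; within the scatter), lies within the scatter, so the readings for the two compounds cannot be told apart. At this aromatic carbon of the five-membered aromatic ring with 2 nitrogen, methylsulfanyl brings 2 heavy atoms and 1 hydrogen-bond acceptor where bromo brings 1 heavy atom and no acceptor, and this exchange produces no shift beyond the scatter in this single pair. Compound 1 and compound 2 could not show this, since they differ from the other compounds in more than one place and their readings are limits, not numbers: the limit of > 64000 nM in this assay, at which 2 of the 4 values shown sit.

The compounds shown leave open whether an amine or a carboxylic acid on this aromatic carbon would also read within the scatter of compound 3 at 34000 nM. Within the data shown here, they also leave open how the nitro group at this carbon compares with bromo or methylsulfanyl, as no pair isolates that exchange on an otherwise unchanged structure.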